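The compounds below may be only part of what the source reports. "The series", "measured", "known", "first", "only" and "open" are said of these compounds alone.

Among the compounds with values here, compound 1 `CCCCCCOc1nc(C(C)(C)C)ccc1CNC(=O)C(C)c1ccc(NS(C)(=O)=O)c(F)c1` gives 2.7 nM in an assay on cells for antagonist activity at transient receptor potential cation channel subfamily V member 1 (Homo sapiens), read by FLIPR and calcium flux, with a stated time of 6 min (on this read-out higher numbers stand for weaker inhibition and lower numbers for stronger inhibition), the lowest of the two numbers measured so far. Compound 2 `CC(C(=O)NCc1ccc(C(C)(C)C)nc1SCCCN(C)C)c1ccc(NS(C)(=O)=O)c(F)c1` gives 51.8 nM in this assay; the step of a 19-fold higher number from compound 1 to compound 2 (1.28 log units; beyond the scatter) goes with (3-(dimethylamino)propyl)sulfanyl in place of hexyloxy on an aromatic carbon. Compound 3 `CCCCCc1nc(C(C)(C)C)ccc1CNC(=O)C(C)c1ccc(NS(C)(=O)=O)c(F)c1` differs from compound 1 by pentyl in place of hexyloxy on an aromatic carbon. This change sits on the same aromatic carbon as the change that gave compound 2, but is a smaller one, so a smaller step than that is expected in this assay, probably towards a higher number. Compound 3 is estimated at 6 nM, within 2 nM to 20 nM, the expected step being a 2.2-fold higher number from compound 1 to compound 3 (0.35 log units; beyond the scatter).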

Compound 3, inhibition constant: 1.9 nM
Beside the measured number, compound 3's estimate is 3.2-fold (0.50 log units) above it, and the stated range ends above it.
By their numbers in this assay, from the lowest: compounds 3 and 1 (each within the scatter of the next); then compound 2.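

In this assay the all-carbon pentyl chain replaces hexyloxy with a 1.4-fold lower number from compound 1 to compound 3 (0.15 log units; within the scatter), so the chain oxygen is not needed at this position for a low number. The contrasting a 27-fold lower number from compound 2 to compound 3 (1.44 log units; beyond the scatter) sets (3-(dimethylamino)propyl)sulfanyl apart from both other chains. Nothing on hand explains this difference.

Compound 2 changes the linking atom and the chain end together, so their contributions cannot be separated. As far as these compounds go, it remains open whether a dimethylamino-ended chain linked through oxygen or carbon, or a much shorter propyl chain, would keep the number low.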